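This account rests on a few compounds, and the source may have more. Where it says the series, first, only, none or still open, it means among the compounds named here.

Compound 2 `O=C(O)CCCC/C=C(\c1cccnc1)c1cccc(Br)c1` gives 180 nM in an assay (Equus caballus) for inhibition of Thromboxane-A synthase (Homo sapiens), using microsomes (a higher number here means a weaker inhibitor, a lower number a stronger inhibitor), the lowest of the two numbers recorded. Its nearest neighbour, compound 1 `O=C(O)CCC/C=C(/c1ccccc1)c1cccnc1`, gives 280 nM in this assay; the gap between compound 2 and compound 1 lies within the scatter, so the two read as equivalent. Compound 3 `Cc1ccsc1/C(=C/CCCCC(=O)O)c1cccnc1` has not yet been measured. It differs from compound 2 in one place: 3-methylthiophen-2-yl in place of 3-bromophenyl on a double-bonded chain carbon bound to an aromatic carbon and a double-bonded chain carbon. The 3-methylthiophen-2-yl ring is a five-membered aromatic ring with one hetero atom and one hydrogen-bond acceptor, while the bromophenyl it replaces is a six-membered carbocycle with none. Among the compounds with values here, no measured pair shows what this exchange does, so the size of the step is uncertain; the step from compound 2 to compound 3 is expected to be small, a 1.4-fold higher number from compound 2 to compound 3 (0.14 log units; within the scatter), with no clear direction beyond the scatter. In this assay compound 3 is therefore expected to give about 250 nM, most plausibly between 80 nM and 800 nM.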

Compound 3, half-maximal inhibitory concentration: 29 nM
Beside the measured number, compound 3's estimate is 8.6-fold (0.94 log units) above it, outside the stated range (below it).
By their numbers in this assay, from the lowest: compound 3; then compounds 2 and 1 (each within the scatter of the next).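

The group on this double-bonded chain carbon turns out to matter in this assay: 3-methylthiophen-2-yl in place of 3-bromophenyl gives a 6.2-fold lower number from compound 2 to compound 3 (0.79 log units; beyond the scatter) and so moves the number well outside the scatter. Within the data shown here, compound 1 and compound 2 differ in more than one place and gave no step at this position, so this is the first sign that the position responds to the identity of the ring. Nothing measured on the compounds shown accounts for the gain.

As far as these compounds go, the exchange alters the ring, its hetero atom and the substituent together, so it remains open which of these carries the gain. A plain thiophen-2-yl and a 3-methylphenyl at this place would separate them, and a 3-methylfuran-2-yl would test the ring sulfur.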